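The compounds below may be only part of what the source reports. "The series", "measured", "known", "first", "only" and "open" are said of these compounds alone.

Measured so far:
- compound 1 `COc1ccc(C(=O)c2ccc(OC)c3c2C=CC(C)(C)O3)c(NC(=O)CBr)c1`: 2150 nM
- compound 2 `COc1ccc(C(=O)c2ccc3c(c2)C=CC(C)(C)O3)c(NC(=O)CO)c1`: 130 nM
- compound 3 `COc1ccc(C(=O)c2ccc(OC)c3c2OC(C)(C)C=C3)c(NC(=O)CN(C)C)c1`: 790 nM

In a functional assay on A2780 cells (Homo sapiens) for antiproliferative activity, read by MTT assay, with a stated time of 48 h (on this read-out lower numbers stand for stronger inhibition and higher numbers for weaker inhibition), compound 1 gives the highest number of the three, 2150 nM, which makes it the weakest of the set. Among the others, compound 3 lies nearest to it at 790 nM, and compound 2 lies furthest at 130 nM.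

The next compound to be tested, compound 4 `COc1ccc(C(=O)c2ccc(OC)c3c2C=CC(C)(C)O3)c(NC(=O)CN(C)C)c1`, keeps the core of compound 1 and changes one group: dimethylamino in place of bromo on a saturated chain carbon bound to a carbonyl carbon. In words, dimethylamino stands in place of bromo on a saturated chain carbon bound to a carbonyl carbon.

Going by the values given here, no step between measured compounds isolates this change, so any expectation rests on indirect evidence. Among the compounds with values here, on a core that is not the one of compound 1, the closest guide is compound 3, which also bears the dimethylamino group and gives 790 nM. Compound 2 offers no direct guide to this exchange. A moderate move toward a lower number in this assay therefore seems likely, beyond the scatter but not a large one. The expected change is a 2.7-fold lower number from compound 1 to compound 4 (0.43 log units; beyond the scatter). For compound 4 the estimated value is 800 nM, with an expected range of 250 nM to 2500 nM.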

Compound 4, half-maximal inhibitory concentration: 3990 nM
Estimate against measurement, compound 4: 5.0-fold (0.70 log units) below, outside the stated range (above it).
By their numbers in this assay, from the lowest: compound 2; then compound 3; then compounds 1 and 4 (each within the scatter of the next).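

In this assay, going by these compounds alone, placing dimethylamino in place of bromo on a saturated chain carbon bound to a carbonyl carbon gives a 1.9-fold higher number from compound 1 to compound 4 (0.27 log units; within the scatter), the first direct reading of any change at this position on the core of compound 1. On this core, the two groups cannot be told apart in this read-out, although dimethylamino brings in more heavy atoms and a hydrogen-bond acceptor that bromo lacks. No measurement of any property of these compounds bears on this result, so the data offer no explanation for it.

The compounds shown leave open whether a primary amine, a carboxylic acid or a longer chain ending in dimethylamino at this place would separate from bromo and dimethylamino on the core of compound 1. They also leave open what hydroxy would give on that core, since compound 2, which carries hydroxy and gives 130 nM, also differs from compound 1 in its core, and its value cannot be assigned to that group alone.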